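The compounds below may be only part of what the source reports. "The series", "measured", "known", "first", "only" and "open" are said of these compounds alone.

Working notes on a small series of halogen swaps. Compound 1 `NC(=O)c1c(NC(=O)c2ccccc2Cl)sc2c1CCN(C(=S)Nc1ccccc1F)C2` gives 28700 nM in a functional assay on HeLa cells (Homo sapiens) for antiproliferative activity, with a stated time of 24 h; a lower number here means a stronger inhibitor, a higher number a weaker inhibitor. Compound 2 `NC(=O)c1c(NC(=O)c2ccccc2Cl)sc2c1CCN(C(=S)Nc1ccccc1Br)C2` differs from compound 1 by bromo in place of fluoro on an aromatic carbon. In this assay compound 2 gives 24600 nM; the change produced a 1.2-fold lower number from compound 1 to compound 2 (0.07 log units; within the scatter). Compound 3 `NC(=O)c1c(NC(=O)c2ccccc2F)sc2c1CCN(C(=S)Nc1ccccc1Cl)C2` gives 19400 nM; the difference between its core and that of compound 1 is not broken down here. Compound 4 `NC(=O)c1c(NC(=O)c2ccccc2Br)sc2c1CCN(C(=S)Nc1ccccc1Cl)C2` has not yet been measured; it differs from compound 3 by bromo in place of fluoro on an aromatic carbon, the same change as from compound 1 to compound 2, in both cases at a place that reads the same. Because a 1.2-fold lower number from compound 1 to compound 2 (0.07 log units; within the scatter) stayed within the scatter, the expected step to compound 4 is likewise small, a 1.2-fold lower number from compound 3 to compound 4 (0.08 log units; within the scatter). Compound 4 is therefore estimated at 16000 nM in this assay, with a likely range from 7000 nM to 35000 nM.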

Compound 4, half-maximal inhibitory concentration: 46900 nM
The estimate for compound 4 lay 2.9-fold (0.47 log units) below the measured number; measured number above the stated range.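

Bromo in place of fluoro gives a 2.4-fold higher number from compound 3 to compound 4 (0.38 log units; beyond the scatter) in this assay, so this change cannot be assumed to carry over unchanged from one core to another in this series: the same change on two cores in this assay, a 1.2-fold lower number (0.07 log units; within the scatter) from compound 1 to compound 2 and a 2.4-fold higher number (0.38 log units; beyond the scatter) from compound 3 to compound 4, 2.8-fold (0.45 log units) apart, beyond the scatter of two such steps

For the compounds shown here, this rests on only two steps, so it shows that the outcome of the change depends on its setting, but not which difference between the cores accounts for that. It also gives no basis for predicting the step on a further core.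

Only halogens stand at the changed place in the compounds shown. On these data alone, how a methoxy group or a nitrile at that place would read in this assay stays open, as does whether the step from fluoro to bromo would repeat on other cores.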